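Thiazolidinedione ether amides: benzothiazole to methylisoxazole

A few compounds are considered here, and "the series" means these few. Any claim that something is new, unique, unknown or untested is made for them only; others in the source may bear on it.

Measured so far in a functional assay on KB cells (Homo sapiens) for cytotoxicity, read by sulforhodamine B assay, with a stated time of 48 h; on this read-out lower numbers stand for stronger inhibition of growth and higher numbers for weaker inhibition of growth:
compound 1 `Cc1c(NC(=O)COc2ccc(/C=C3\SC(=O)NC3=O)cc2)c(=O)n(-c2ccccc2)n1C`: < 100000 nM (a limit of the assay)
compound 2 `CCCCC1=NC2(CCCC2)C(=O)N1C(=O)COc1ccc(/C=C2/SC(=O)NC2=O)cc1`: < 100000 nM (a limit of the assay)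
compound 3 `O=C(COc1ccc(/C=C2\SC(=O)NC2=O)cc1)Nc1nc2ccccc2s1`: < 100000 nM (a limit of the assay)

In this assay compound 3 gives only a limit, < 100000 nM, and not a number. Where it stands is therefore known only through (the limit of < 100000 nM in this assay, at which 3 of the 3 values shown sit), and no step between measured compounds can be sized. Compound 4 `Cc1cc(NC(=O)COc2ccc(/C=C3\SC(=O)NC3=O)cc2)no1` differs from compound 3 in one place: 5-methyl-1,2-oxazol-3-yl in place of 1,3-benzothiazol-2-yl on an amide-type nitrogen. With every neighbour sitting at the same limit, no direction for this change can be read from the data. The step from compound 3 to compound 4 is expected to be a step that the limit leaves unreadable from compound 3 to compound 4, not beyond the usual scatter. Compound 4 is estimated to give 40000 nM, within 5000 nM to 100000 nM, most likely again reported as a limit.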

Compound 4, concentration for 50% growth inhibition: < 100000 nM
Compound 4 gave a limit, no number (the forecaster's own chance of this, stated with the estimate: 70%); the middle value lies beyond the limit too.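

No step can be read between compound 3 and compound 4, since both give only a limit: the limit of < 100000 nM in this assay, at which 4 of the 4 values shown sit.

The compounds shown leave open how strongly each inhibits growth in this assay, and whether 5-methyl-1,2-oxazol-3-yl and 1,3-benzothiazol-2-yl differ there at all.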